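Replacing one side group of compound 1

A few compounds are considered here, and "the series" means these few. Any claim that something is new, unique, unknown or untested is made for them only; others in the source may bear on it.

Measured compounds:
compound 1 `C[C@@H]1CC(c2cnc3c(C#N)nn([C@H](C)c4ccc(Cl)cc4Cl)c3n2)=CC[C@@H]1N1CCC[C@H]1C(C)(C)O`: "not determined" (no result reported)
compound 2 `Cc1nn([C@H](C)c2ccc(Cl)cc2Cl)c2nc(C3=CC[C@H](N4CCC[C@H]4CO)[C@H](C)C3)cnc12`: 35%

In an ADME assay on cells (Hepatocyte, Rattus norvegicus) for metabolic stability, read by LC-MS, with a stated time of 60 min (a lower number here means that less of the compound is left, a higher number that more of the compound is left), compound 1 stands at "not determined" (no result reported), so it offers no number to start from. The only figure available is from compound 2, at 35%. The unmeasured compound 3 `C[C@@H]1CC(c2cnc3c(C#N)nn([C@H](C)c4ccc(Cl)cc4Cl)c3n2)=CC[C@@H]1N1CCC[C@H]1C(N)=O` departs from compound 1 in one place. The change is carbamoyl in place of 1-hydroxy-1-methylethyl on a saturated ring carbon. Going by the values given here, no measured step supports a size for this change, but a moderate upward step, slightly beyond the usual scatter, is expected. For compound 3 the estimated value is 48%, with an expected range of 22% to 78%.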

Compound 3, percent of the compound remaining: 71%
Beside the measured number, compound 3's estimate is 23 percentage points below it; the range from low to high includes it.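

Going by these compounds alone, compound 1 has no number to set beside compound 3 at 71% and so no step between them can be read. How far carbamoyl in place of 1-hydroxy-1-methylethyl shifts the compound remaining stays open, and nothing shown explains this result.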